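This account rests on a few compounds, and the source may have more. Where it says the series, first, only, none or still open, it means among the compounds named here.

Measured so far:
Compound 1 `CN1CCC(CNS(=O)(=O)c2ccccc2Nc2cc(-c3ccc4ccn(C)c4c3)c3nccnc3c2)C1` gives 35 ug/mL in a physicochemical assay for solubility, read by spectrophotometry, measured as kinetic solubility, at pH 8, tested at 500 uM; a higher number here means a more soluble compound, a lower number a less soluble compound.
Compound 2 `CN(C)C(=O)c1ccncc1Nc1cc(-c2ccc3ccn(C)c3c2)c2nccnc2c1` gives 175 ug/mL in this assay.

Of the two numbers, compound 2 stands highest, and the gap down to compound 1 is beyond the usual scatter, so the two compounds are clearly told apart. The two structures differ in several places at once, so the comparison says nothing about any one group.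

Compound 3 `CN1CCC(N(C)C(=O)c2ccncc2Nc2cc(-c3ccc4ccn(C)c4c3)c3nccnc3c2)C1` has not yet been measured. It differs from compound 2 in one place: 1-methylpyrrolidin-3-yl in place of methyl on an amide-type nitrogen. For the measured compounds named here, no measured pair shows this same change on this core, so there is no directly comparable step to lean on. With compound 2 already high in this assay, the change is expected to move the number little, either way, and likely within the scatter.

Compound 3 is therefore estimated at 160 ug/mL, within a range from 70 ug/mL to 280 ug/mL, which means an expected step of a 1.1-fold lower number from compound 2 to compound 3 (0.04 log units; within the scatter).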

Compound 3, solubility: 245 ug/mL
Compound 3: middle estimate off by 1.5-fold (0.19 log units), on the low side; the range from low to high includes it.
By their numbers in this assay, from the lowest: compound 1; then compounds 2 and 3 (each within the scatter of the next).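

Putting 1-methylpyrrolidin-3-yl in place of methyl on the amide-type nitrogen gives a 1.4-fold higher number from compound 2 to compound 3 (0.15 log units; within the scatter) in this assay, so the two compounds cannot be told apart. This pair therefore shows that a group of 6 heavy atoms, carrying a five-membered ring and a nitrogen, can stand at this position with no clear shift in the read-out, which the comparison of compound 1 with compound 2 could not show, as those two differ in several places. Nothing measured here explains the result.

Still open, on these data alone, is whether the ring or its nitrogen counts for more, which cyclopentyl or an open dimethylaminoethyl chain on the same nitrogen could help to separate. As far as these compounds go, whether the same change behaves alike on a different core also remains unknown.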